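A few compounds are considered here, and "the series" means these few. Any claim that something is new, unique, unknown or untested is made for them only; others in the source may bear on it.

The measured compounds, each with its result:

Compound 1, `Cc1[nH]c2ccccc2c1C(c1ccccc1)c1cc2ccccc2o1`, gives 56500 nM in a functional assay on SiHa cells (Homo sapiens) for cytotoxicity; a higher number here means a weaker inhibitor, a lower number a stronger inhibitor.
Compound 2, `COc1ccc2oc(C(c3ccccc3)c3c[nH]c4ccccc34)cc2c1`, reaches only the limit of this assay, reported as > 100000 nM, which is a boundary of the measurement and not a number.
Compound 3, `CC(C)(C)c1cc(C(C)(C)C)c2oc(C(c3ccccc3)c3c[nH]c4ccccc34)cc2c1`, gives 61600 nM in this assay.

All three share the same core and differ only in the substituents on the furan-fused ring. Of the two numbers, compound 3 and compound 1 lie within the usual scatter of each other, so neither can be called the stronger or the weaker inhibitor. The limit for compound 2 is stated in the limit of > 100000 nM in this assay, at which 1 of the 3 values shown sits.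

Compound 4, `CC(C)(C)c1cc(C(C)(C)C)c2oc(C(c3ccccc3)c3c[nH]c4ccc([N+](=O)[O-])cc34)cc2c1`, differs from compound 3 in one place: nitro in place of hydrogen on an aromatic carbon, reading 1H-indol-3-yl to 5-nitro-1H-indol-3-yl. Among the compounds with values here, no pair of measured compounds shows this change, so no measured step gives its size. With nothing to point either way, the expected step from compound 3 to compound 4 is a 1.2-fold lower number from compound 3 to compound 4 (0.09 log units; within the scatter) in this assay, none beyond the scatter. Compound 4 is therefore estimated at 50000 nM, with a range from 15000 nM to 100000 nM.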

Compound 4, half-maximal inhibitory concentration: 48200 nM
The estimate for compound 4 lay 1.0-fold (0.02 log units) above the measured number, within the range that was stated.
By their numbers in this assay, from the lowest: compounds 4, 1 and 3 (each within the scatter of the next). At a limit, above all of these: compound 2.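

The change from 1H-indol-3-yl to 5-nitro-1H-indol-3-yl gives a 1.3-fold lower number from compound 3 to compound 4 (0.11 log units; within the scatter) in this assay, so compound 3 and compound 4 cannot be told apart by this read-out. Within the data shown here, the earlier compounds offered no pair differing in one place, which makes this the only direct reading of a change at this aromatic carbon, and it shows that nitro in place of hydrogen here leaves the number within the usual scatter of repeated measurements. Nothing shown bears on why this step stays within the scatter.

One step with one group cannot show whether this position is insensitive to substitution in general, since an amine or a carboxylic acid at the same aromatic carbon might give a step beyond the scatter in this assay. As far as these compounds go, it also remains open whether nitro would give a similar step on the core of compound 1, because a single pair cannot show whether the step carries over to another substitution pattern.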